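A few compounds are considered here, and "the series" means these few. Any claim that something is new, unique, unknown or untested is made for them only; others in the source may bear on it.

In an ADME assay on microsomes from liver (Rattus norvegicus) for metabolic stability (a lower number here means that the compound disappears faster, a higher number that the compound lasts longer), compound 2 `CC(C)[C@H](C[C@H]1OC(=O)NC1=O)c1ccc(-c2ccc3cccc(F)c3c2)[nH]c1=O` gives 0.95 h and compound 1 `CC(C)[C@@H](c1ccc(-c2ccc3cccc(F)c3c2)[nH]c1=O)[C@@H]1OC(=O)NC1=O` gives 1.27 h, two numbers that lie within the scatter of each other. Compound 3 `CC(C)C(/C=C1\OC(=O)NC1=O)c1cc(Cl)c(-c2ccc3cccc(F)c3c2)[nH]c1=O` is reported only as a limit, > 3 h. Compound 4 `CC(C)[C@@H](c1ccc(-c2ccc3cccc(F)c3c2)[nH]c1=O)[C@H]1OC(=O)NC1=O` has not yet been measured. Its change from compound 2 is 2,4-dioxo-1,3-oxazolidin-5-yl in place of (2,4-dioxo-1,3-oxazolidin-5-yl)methyl on a saturated chain carbon bound to an aromatic carbon and a saturated chain carbon. Among the compounds with values here, only one measured step bears on this exchange, and it runs in the opposite direction: a 1.3-fold lower number from compound 1 to compound 2 (0.13 log units; within the scatter). That step, from compound 1, stays within the scatter, so no change beyond the scatter is expected here, and one step alone gives little support for any direction. The expected step is a 1.3-fold higher number from compound 2 to compound 4 (0.10 log units; within the scatter), a small one that would not stand out from repeated measurements. For compound 4, the estimated half-life is 1.2 h, with an expected range of 0.6 h to 2.4 h.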

Compound 4, half-life: 1.93 h
The estimate for compound 4 lay 1.6-fold (0.21 log units) below the measured number; the range from low to high includes it.
By their numbers in this assay, from the lowest: compounds 2, 1 and 4 (each within the scatter of the next, the first and the last beyond it). At a limit, above all of these: compound 3.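

In this assay, 2,4-dioxo-1,3-oxazolidin-5-yl in place of (2,4-dioxo-1,3-oxazolidin-5-yl)methyl on this saturated chain carbon now gives a modest step that clears the scatter: a 2.0-fold higher number from compound 2 to compound 4 (0.31 log units; beyond the scatter). The same exchange read with compound 1 stayed within the scatter, so the outcome of this change differs with the ring stereocentre as drawn, though only by a small margin. The two compounds carrying the directly attached group remain within the scatter of each other, a 1.5-fold higher number from compound 1 to compound 4 (0.18 log units; within the scatter), so configuration alone gives no firm separation, and the comparison isolates that one feature: the fact that compounds 1 and 4 differ only in the configuration as drawn.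

Compound 3 is known only as a limit, > 3 h, and gives no readable step to the others. On these data alone, how an amine, a carboxylic acid or a longer chain would fare at this carbon remains open.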